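The compounds below may be only part of what the source reports. "The series", "measured", "known", "first", "only" and "open" are said of these compounds alone.

Measured so far in a functional assay on A549 cells (Homo sapiens) for antiproliferative activity, read by MTT assay, with a stated time of 48 h; a lower number here means a stronger inhibitor, a higher number a weaker inhibitor:

- compound 1 `O=C(/C=C/c1cccnc1)Nc1ccc2ncnc(Nc3cccc(Cl)c3)c2c1`: 4320 nM
- compound 2 `Cc1cccc(/C=C/C(=O)Nc2ccc3ncnc(Nc4cccc(Cl)c4)c3c2)n1`: 2160 nM

Compound 2 holds the lower of the two numbers in this assay, but its nearest neighbour is compound 1 and the gap between them, a 2.0-fold lower number from compound 1 to compound 2 (0.30 log units; within the scatter), lies within the scatter; no order between the two can be read from this.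

Compound 3 `O=C(/C=C/c1cccnc1Cl)Nc1ccc2ncnc(Nc3cccc(Cl)c3)c2c1` is not yet measured. The change from compound 2 is 2-chloropyridin-3-yl in place of 6-methylpyridin-2-yl on a double-bonded chain carbon bound to a double-bonded chain carbon. Within the data shown here, the only measured step that touches this position is the one from compound 1 to compound 2, a 2.0-fold lower number from compound 1 to compound 2 (0.30 log units; within the scatter), which swapped pyridin-3-yl for 6-methylpyridin-2-yl and stayed within the scatter. Compound 3 returns to a pyridin-3-yl ring carrying a chlorine, so it sits structurally between the two measured compounds. On this evidence no step beyond the scatter is expected in this assay: the estimated step from compound 2 to compound 3 is a 1.4-fold higher number from compound 2 to compound 3 (0.14 log units; within the scatter). Compound 3 is therefore expected to give about 3000 nM in this assay, with a likely range from 1000 nM to 9000 nM.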

Compound 3, half-maximal inhibitory concentration: 2920 nM
Beside the measured number, compound 3's estimate is 1.0-fold (0.01 log units) above it; the measured number falls inside the stated range.
By their numbers in this assay, from the lowest: compounds 2, 3 and 1 (each within the scatter of the next).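

The series now holds a substitution on the pyridin-3-yl ring itself: in this assay, chloro in place of hydrogen on an aromatic carbon gives a 1.5-fold lower number from compound 1 to compound 3 (0.17 log units; within the scatter) and so does not separate the two compounds. Exchanging 6-methylpyridin-2-yl for 2-chloropyridin-3-yl, with the same count of heavy atoms, gives a 1.4-fold higher number from compound 2 to compound 3 (0.13 log units; within the scatter) and adds a second pair at this position that cannot be ordered, so among these three compounds neither the methyl, the chloro nor the pyridin-2-yl or pyridin-3-yl attachment is separated from the others in this read-out. No supporting data bear on this result.

The compounds shown leave open whether any group on this ring can produce a step beyond the scatter in this assay, since all three pairs so far remain within it. An amine or a carboxylic acid on the pyridine ring, or a longer chain in place of the ethenyl link, would test the position in a way that methyl and chloro do not.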